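The source may report more compounds than this note shows. Statements on the series, on what has been measured and on what is new or still open speak of the compounds shown alone.

Compound 1 `O=S(=O)(NCCN1CCCCCC1)c1ccc(I)cc1` has been measured in an assay on membranes from brain (Cavia porcellus) for binding affinity to Sigma non-opioid intracellular receptor 1 (Homo sapiens) (on this read-out lower numbers stand for stronger inhibition and higher numbers for weaker inhibition), where compound 1 gives 1.32 nM. Of the two numbers recorded so far this is the higher one; the nearest is compound 2 `O=S(=O)(NCCN1CCCCCC1)c1ccc(Br)cc1`, which in this assay gives 0.63 nM. Going by the values given here, the single measured step between them is a 2.1-fold lower number from compound 1 to compound 2 (0.32 log units; beyond the scatter), a change on an aromatic carbon. Compound 3 `CN(CCN1CCCCCC1)S(=O)(=O)c1ccc(I)cc1` is not yet measured; it differs from compound 1 by methyl in place of hydrogen on a sulfonamide nitrogen. Among the compounds with values here, no measured step touches the sulfonamide nitrogen, so the halogen swap offers no direct guide to this change. With nothing in the numbers pointing either way, the expected step in this assay is a 1.5-fold higher number from compound 1 to compound 3 (0.18 log units; within the scatter), a size that may well sit within the usual scatter. For compound 3 the estimate in this assay is 2 nM, with a range from 0.7 nM to 6 nM.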

Compound 3, inhibition constant: 0.14 nM
Estimate against measurement, compound 3: 14-fold (1.15 log units) above; the whole stated range lies above it.
By their numbers in this assay, from the lowest: compound 3; then compound 2; then compound 1.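

In this assay, methyl in place of hydrogen on the sulfonamide nitrogen gives a 9.4-fold lower number from compound 1 to compound 3 (0.97 log units; beyond the scatter) and so shows that, with iodo on the ring, this nitrogen does not need its hydrogen for a low number. This step is larger than the only other one available, a 2.1-fold lower number from compound 1 to compound 2 (0.32 log units; beyond the scatter) for bromo in place of iodo on an aromatic carbon, which makes the sulfonamide nitrogen a sensitive place in this short series. Nothing measured here bears on why the number falls.

Going by these compounds, whether an ethyl group or a longer chain on that nitrogen would lower the number further remains open. So does whether methyl there would have a similar effect in the bromo compound, compound 2, since one step on one compound cannot show how general the change is.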